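The source may report more compounds than this note shows. Statements on the series, on what has been measured and on what is new or still open speak of the compounds shown alone.

Working notes on the series. Compound 1 `N#Cc1ccc(Nc2nc(Oc3ccnc4ccccc34)nc(N3CCN(c4ccccc4Cl)CC3)n2)cc1C(F)(F)F` carries a 2-chlorophenyl on the piperazine nitrogen. In a functional assay on DU-145 cells (Homo sapiens) for cytotoxicity, read by sulforhodamine B assay, with a stated time of 48 h (a lower number here means a stronger inhibitor of growth, a higher number a weaker inhibitor of growth), compound 1 gives > 100000 nM, which is a limit of the assay and not a number. Compound 2 `N#Cc1ccc(Nc2nc(Oc3ccnc4ccccc34)nc(N3CCN(c4ccccc4)CC3)n2)cc1C(F)(F)F` has hydrogen in place of chloro on an aromatic carbon. In this assay compound 2 also reaches only the limit > 100000 nM. Compound 3 `N#Cc1ccc(Nc2nc(Oc3ccnc4ccccc34)nc(N3CCN(Cc4ccccc4)CC3)n2)cc1C(F)(F)F` has benzyl in place of phenyl on the amine nitrogen in the ring. Compound 3 likewise gives the limit > 100000 nM. Going by the values given here, every value so far sits at the limit of > 100000 nM in this assay, at which 3 of the 3 values shown sit, so compound 2 stands nowhere apart from compounds 1 and 3: the steps a step that the two limits leave unreadable from compound 1 to compound 2, a step that the two limits leave unreadable from compound 1 to compound 3 and a step that the two limits leave unreadable from compound 2 to compound 3 cannot be read, both ends of each being limits.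

Compound 4 `CC1CC(C)CN(c2nc(Nc3ccc(C#N)c(C(F)(F)F)c3)nc(Oc3ccnc4ccccc34)n2)C1` is the unmeasured member. Against compound 2 it shows (3,5-dimethylpiperidin-1-yl in place of 4-phenylpiperazin-1-yl on an aromatic carbon). The new group sits on the carbon of the shared core between two ring nitrogen atoms, meta to the (quinolin-4-yl)oxy group. All three measured steps vary this same position, and none gives a size; they show only that every variation here has left the value at the limit. The expected step that the limit leaves unreadable from compound 2 to compound 4 is therefore none that can be read, with compound 4 most likely remaining at the limit. Compound 4 is estimated at 150000 nM, within 30000 nM to 600000 nM.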

Compound 4, concentration for total growth inhibition: 68000 nM
The estimate for compound 4 lay 2.2-fold (0.34 log units) above the measured number; the range from low to high includes it.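

Compound 4 is the only compound shown whose value at this position falls within the readable range of this assay, so this position can carry a group that gives a number rather than a limit. Replacing 4-phenylpiperazin-1-yl with the smaller 3,5-dimethylpiperidin-1-yl, which has no aromatic ring and one hetero atom fewer, gives an at least 1.4-fold lower number from compound 2 to compound 4 (0.16 log units; that floor lies within the scatter), so the data show a readable end point but no change demonstrably beyond the scatter. Compounds 1, 2 and 3 remain limits, not numbers, and the steps among them cannot be read: the limit of > 100000 nM in this assay, at which 3 of the 4 values shown sit.

Compound 4 differs from compound 2 at once in the loss of the phenyl ring, the loss of the second ring nitrogen and the gain of two methyl groups, so the compounds shown do not assign the number to any one of these. From the compounds shown here alone, a plain piperidin-1-yl, a morpholin-4-yl or an open-chain diethylamino group at this position would separate these parts, and how far the value can fall with any group here remains open.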